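Replacing the Pyrrolidinylmethyl Anilide by a Chloroanilide

The source may report more compounds than this note shows. Statements on the series, on what has been measured and on what is new or still open speak of the compounds shown alone.

Compound 1 `O=C(Nc1cccc(Oc2ccccn2)c1)C1CCCN(C(=O)c2cc(C(F)(F)F)cc(C(F)(F)F)c2)C1` gives 0% in an ADME assay on PC-3 cells (Homo sapiens) for cytotoxicity, read by WST assay, tested at 100 uM; a higher number here means more inhibition at the concentration tested (going by the name of the read-out), a lower number less inhibition.
Compound 2 `O=C(Nc1cccc(CN2CCCC2)c1)C1CCCN(C(=O)c2cc(C(F)(F)F)cc(C(F)(F)F)c2)C1` gives 51% in this assay.
Compound 3 `O=C(Nc1cccc(Cc2ccccc2)c1)C1CCCN(C(=O)c2cc(C(F)(F)F)cc(C(F)(F)F)c2)C1` gives 0% in this assay.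

Compound 2 stands highest of the three measurements: compound 1 and compound 3 both lie below it, and both gaps are beyond the scatter. The two single-point changes that reach compound 2 are a number 51 percentage points higher from compound 1 to compound 2 (beyond the scatter) and a number 51 percentage points lower from compound 2 to compound 3 (beyond the scatter), while between compound 1 and compound 3 there is no change at the digits printed from compound 1 to compound 3 (within the scatter).

Compound 4 `O=C(Nc1ccc(Cl)cc1)C1CCCN(C(=O)c2cc(C(F)(F)F)cc(C(F)(F)F)c2)C1` differs from compound 2 in one place: 4-chlorophenyl in place of 3-((pyrrolidin-1-yl)methyl)phenyl on an amide-type nitrogen. Among the compounds with values here, the step that bears on this is the one from compound 2 to compound 3, in which the pyrrolidin-1-yl alone leaves and the read-out falls to the level of compound 1 and compound 3. In compound 4 the entire 3-((pyrrolidin-1-yl)methyl)phenyl leaves, so a fall of comparable size is expected, a number 46 percentage points lower from compound 2 to compound 4 (beyond the scatter). Compound 4 is therefore estimated at 5%, with a range from 0% to 25%.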

Compound 4, a percentage reported as inhibition, at one concentration (the size of the read-out at that concentration, not a potency): 14%
Compound 4: the middle estimate sits 9 percentage points below what was measured; low and high end bracket the measured number.
By their numbers in this assay, from the lowest: compounds 1 and 3 (each within the scatter of the next); then compound 4; then compound 2.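

On the amide-type nitrogen, exchanging the whole 3-((pyrrolidin-1-yl)methyl)phenyl for 4-chlorophenyl costs much of the read-out in this assay, with a number 37 percentage points lower from compound 2 to compound 4 (beyond the scatter). An aryl ring on that nitrogen is therefore not enough to keep the level of compound 2, since compound 4 retains a six-membered aromatic ring of carbon only and gives 14% in this comparison. Nothing measured here explains the fall.

The change removes the pyrrolidine and introduces chlorine in a single step, so the compounds shown leave open which of the two accounts for the difference. Also open, as far as these compounds go, is how the read-out would respond if a (dimethylamino)methyl group or a piperidine took the place of the pyrrolidine on this aryl ring.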